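The source may hold more compounds than are shown below. What is called first, only, known or untested is meant among the compounds shown, and "the series" means these compounds.

Measured in a functional assay on NCI-H23 cells (Homo sapiens) for antiproliferative activity, read by sulforhodamine B assay; a higher number here means a weaker inhibitor of growth, a lower number a stronger inhibitor of growth:
Compound 1 `CC(C)=CCOc1cccc(O)c1C(=O)/C=C/c1ccc(O)cc1`: > 30000 nM
Compound 2 `O=C(/C=C/c1ccc(O)cc1)c1c(O)cccc1OCC1CCCCC1`: > 30000 nM

Compound 2 gives > 30000 nM, which is a limit of the assay and not a number. Compound 1 gives > 30000 nM, also a limit. Neither compound therefore has a readable value, and the record stands as the limit of > 30000 nM in this assay, at which 2 of the 2 values shown sit.

Compound 3 `CCC(CC)COc1cccc(O)c1C(=O)/C=C/c1ccc(O)cc1` has not yet been measured. It keeps the core of compound 2 and differs from it in one place: pentan-3-yl in place of cyclohexyl on a saturated chain carbon bound to an oxygen on an aromatic ring. In words, pentan-3-yl stands in place of cyclohexyl on a saturated chain carbon bound to an oxygen on an aromatic ring.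

Going by the values given here, the only measured step at this place is a step that the two limits leave unreadable from compound 1 to compound 2, so it gives no size to carry over. The two limits show only that neither the 2-methylprop-1-en-1-yl nor the cyclohexyl compound gave a number in this assay. No step beyond the scatter is therefore expected, in either direction, and a further limit is the likeliest result. The expected change is a number no higher from compound 2 to compound 3 (the limit leaves the size open). For compound 3 the estimated value is 30000 nM, with an expected range of 12000 nM to 40000 nM.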

Compound 3, concentration for 50% growth inhibition: 3210 nM
Compound 3: the middle estimate sits 9.3-fold (0.97 log units) above what was measured; measured number outside the range, below it.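

In this assay, going by these compounds alone, the chain carbon bound to an oxygen on an aromatic ring now proves able to carry a group that gives a readable number, which the earlier compounds could not show, as compound 1 and compound 2 each stay at a limit of the assay and not a number: the limit of > 30000 nM in this assay, at which 2 of the 3 values shown sit. Pentan-3-yl in place of cyclohexyl gives an at least 9.3-fold lower number from compound 2 to compound 3 (0.97 log units; beyond the scatter) and pentan-3-yl in place of 2-methylprop-1-en-1-yl gives an at least 9.3-fold lower number from compound 1 to compound 3 (0.97 log units; beyond the scatter), so the position responds to the shape of the group it carries, and both steps lie beyond the scatter. Compound 1 also carries no ring in this group and stays at a limit, so the loss of the ring from cyclohexyl does not alone account for the step.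

Going by these compounds, the step between compound 1 and compound 2 cannot be read, and the true size of the two new steps stays open, as each starts from a limit. On these data alone, whether a longer branched chain such as 2-propylpentyl, or an amine at the end of the chain, would lower the number further also remains open.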